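Ethyl to ethynyl on an antiproliferative hydroxamic acid series

The source may report more compounds than this note shows. Statements on the series, on what has been measured and on what is new or still open speak of the compounds shown alone.

- compound 1 `Cc1ccccc1Nc1ncnc2cc(NC(=O)CCCCCCC(=O)NO)sc12`: 1750 nM
- compound 2 `COc1ccc(Nc2ncnc3cc(NC(=O)CCCCCCC(=O)NO)sc23)c(C)c1`: 1980 nM
- compound 3 `CCc1cccc(Nc2ncnc3cc(NC(=O)CCCCCCC(=O)NO)sc23)c1`: 1570 nM

In a functional assay on RPMI-8226 cells (Homo sapiens) for antiproliferative activity, read by radiometric assay, with a stated time of 72 h (on this read-out lower numbers stand for stronger inhibition and higher numbers for weaker inhibition), compound 3 gives 1570 nM, and it cannot be separated from the other two. The steps that reach it are a 1.1-fold lower number from compound 1 to compound 3 (0.05 log units; within the scatter) and a 1.3-fold lower number from compound 2 to compound 3 (0.10 log units; within the scatter). Compound 4 `C#Cc1cccc(Nc2ncnc3cc(NC(=O)CCCCCCC(=O)NO)sc23)c1` carries ethynyl in place of ethyl on an aromatic carbon, meta to a large group: ethynyl in place of ethyl on an aromatic carbon. Among the measured compounds shown here, no measured step makes this exact exchange. The closest evidence is those two steps, together with a 1.1-fold higher number from compound 1 to compound 2 (0.05 log units; within the scatter), and all three stay within the scatter. Three compounds are a narrow base, but no shift beyond the scatter is expected in this assay. The expected change is a 1.0-fold lower number from compound 3 to compound 4 (0.02 log units; within the scatter). Compound 4 is estimated at 1500 nM, with an expected range of 800 nM to 2800 nM.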

Compound 4, half-maximal inhibitory concentration: 970 nM
Compound 4: the middle estimate sits 1.5-fold (0.19 log units) above what was measured; the measured number falls inside the stated range.
By their numbers in this assay, from the lowest: compounds 4, 3, 1 and 2 (each within the scatter of the next, the first and the last beyond it).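

Ethynyl in place of ethyl on this aromatic carbon gives a 1.6-fold lower number from compound 3 to compound 4 (0.21 log units; within the scatter) in this assay and so does not move the number beyond the scatter. The wider exchange of the whole aryl group gives a 1.8-fold lower number from compound 1 to compound 4 (0.26 log units; within the scatter) and stays within it, whereas a 2.0-fold lower number from compound 2 to compound 4 (0.31 log units; beyond the scatter) is the only modest step beyond the scatter among these compounds. No evidence here explains these numbers. The compounds shown leave open whether a nitrile or a propynyl group on this carbon would give a similar number, and whether the ethynyl result holds with a shorter or longer chain carrying the hydroxamic acid.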